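The compounds below may be only part of what the source reports. "The series", "measured", "known", "first", "only" and "open" are said of these compounds alone.

Three compounds built on one shared core, differing only in the aromatic group attached to it, have so far been tested in an ADME assay on HEL cells (Homo sapiens) for cytotoxicity, with a stated time of 3 days; on this read-out lower numbers stand for higher toxicity in this test and higher numbers for lower toxicity in this test. Compound 1 `Cc1cc(-c2ccc(O)cc2)c2ncc(CSCCc3ccccc3)n2c1` carries a 4-hydroxyphenyl group and gives 13.7 ug/mL. Among the compounds with values here, compound 3 `Cc1cc(-c2cccc([N+](=O)[O-])c2)c2ncc(CSCCc3ccccc3)n2c1` carries a 3-nitrophenyl group instead and gives 47 ug/mL; the only measured step between two compounds that differ in one place is a 3.4-fold higher number from compound 1 to compound 3 (0.54 log units; beyond the scatter). Compound 2 `Cc1cc(-c2ccccc2)cn2c(CSCCc3ccccc3)cnc12` carries a plain phenyl group and gives 31 ug/mL, the second highest of the three numbers: it sits within the scatter of compound 3, while compound 1 lies clearly lower.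

Compound 4 `Cc1cc(-c2cccs2)cn2c(CSCCc3ccccc3)cnc12` has not yet been measured. Its change from compound 2 is thiophen-2-yl in place of phenyl on an aromatic carbon, a swap of one aromatic group for another on an aromatic carbon of the shared core. Within the data shown here, the one measured step, which also swapped groups at that aromatic carbon, was modest. Among the measured compounds shown here, no measured step here speaks directly to exchanging phenyl for thiophen-2-yl, so the step from compound 2 to compound 4 in this assay is expected to be a 1.0-fold lower number from compound 2 to compound 4 (0.01 log units; within the scatter), within the scatter. For compound 4 a value of 30 ug/mL is therefore estimated, with a likely range from 12 ug/mL to 70 ug/mL.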

Compound 4, half-maximal cytotoxic concentration: 32 ug/mL
The estimate for compound 4 lay 1.1-fold (0.03 log units) below the measured number, and the stated range covers the measured number.
By their numbers in this assay, from the lowest: compound 1; then compounds 2, 4 and 3 (each within the scatter of the next).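

In this assay the exchange of phenyl for thiophen-2-yl gives a 1.0-fold higher number from compound 2 to compound 4 (0.01 log units; within the scatter), so this aromatic carbon of the shared core accepts a five-membered aromatic ring with a sulfur atom in place of a six-membered all-carbon ring without any change that can be told from the scatter. Within the data shown here, the one earlier step, a 3.4-fold higher number from compound 1 to compound 3 (0.54 log units; beyond the scatter), only traded one substituted phenyl group for another, so it gave no view of what happens when the ring itself changes in size and atom make-up, with one heavy atom fewer and one hydrogen-bond acceptor more. Nothing available explains why compound 2 and compound 4 read alike, and this single pair supports no general rule about aromatic rings at this carbon.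

Going by these compounds, it remains open whether a non-aromatic group at this carbon, such as an amine, a carboxylic acid or a longer alkyl chain, would keep the number in the same place. On these data alone, it is also open whether a substituted thiophene or a ring with nitrogen, such as pyridine, would do so.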